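A few compounds are considered here, and "the series" means these few. Any claim that something is new, unique, unknown or untested is made for them only; others in the source may bear on it.

Notes on the series. Among the compounds with values here, the two compounds measured so far share one core. Compound 1 `CCCNC(=O)c1ccc(Oc2nc(-c3c(C)noc3C)cnc2N)cc1` carries a propyl group on the amide-type nitrogen; in a functional assay on U-87MG ATCC cells for inhibition, with U-87 MG (Homo sapiens) as the target, read by MTT assay, with a stated time of 72 h (a higher number here means a weaker inhibitor, a lower number a stronger inhibitor), compound 1 gives 47800 nM. Compound 2 `Cc1noc(C)c1-c1cnc(N)c(Oc2ccc(C(=O)Nc3ccccc3)cc2)n1` carries a phenyl there instead; in this assay compound 2 gives 26600 nM. Within the data shown here, the step of a 1.8-fold lower number from compound 1 to compound 2 (0.25 log units; within the scatter) is the only measured step in the set. Compound 2 thus holds the lower of the two numbers, though compound 1 lies within the scatter of it, so no real order between the two follows.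

Compound 3 `Cc1noc(C)c1-c1cnc(N)c(Oc2ccc(C(=O)Nc3ccccc3Cl)cc2)n1` differs from compound 2 by chloro in place of hydrogen on an aromatic carbon. Among the measured compounds shown here, no measured step touches a substituent on the phenyl of the anilide; the one step available, a 1.8-fold lower number from compound 1 to compound 2 (0.25 log units; within the scatter), concerns the exchange of the whole group on the amide-type nitrogen and bears only loosely on the present change. With nothing in the data pointing in either direction, the expectation for this assay is no step beyond the scatter. Compound 3 is therefore expected to give 20000 nM in this assay, with a range from 7000 nM to 60000 nM. The step of a 1.3-fold lower number from compound 2 to compound 3 (0.12 log units; within the scatter) is accordingly estimated to lie within the scatter.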

Compound 3, half-maximal inhibitory concentration: 60500 nM
Compound 3: the middle estimate sits 3.0-fold (0.48 log units) below what was measured, and the stated range ends below it.
By their numbers in this assay, from the lowest: compounds 2, 1 and 3 (each within the scatter of the next, the first and the last beyond it).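

In this assay, within the data shown here, chloro in place of hydrogen on an aromatic carbon, ortho to a large group, gives a 2.3-fold higher number from compound 2 to compound 3 (0.36 log units; beyond the scatter); this is the first step in the set beyond the scatter, though a modest one, and it shows that the number in this assay responds to a change at this position on the phenyl. Read against the propyl group, the 2-chlorophenyl group gives a 1.3-fold higher number from compound 1 to compound 3 (0.10 log units; within the scatter), so no order follows for that pair, and the phenyl and propyl groups likewise remain unordered by a 1.8-fold lower number from compound 1 to compound 2 (0.25 log units; within the scatter). No supporting measurement bears on this shift, so the data show its size and direction but not its origin.

A single substituent at a single place leaves open whether fluoro, methoxy or a carboxylic acid at the same position would move the number the same way, and whether chloro elsewhere on the ring would do so. As far as these compounds go, it is also open whether an amine or a longer chain on the amide-type nitrogen would give a step beyond the scatter from compound 1.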